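The source may hold more compounds than are shown below. What is called first, only, known or untested is meant among the compounds shown, and "the series" means these compounds.

Measured compounds in an ADME assay on Vero cells (Chlorocebus sabaeus) for cytotoxicity; on this read-out higher numbers stand for lower toxicity in this test and lower numbers for higher toxicity in this test:
- compound 1 `Fc1ccc(-c2nn3c(NC4CCCC4)cccc3c2-c2ccc(F)nc2)cc1`: compound 1 gives "not determined" (no result reported)
- compound 2 `Nc1nccc(-c2c(-c3ccc(F)cc3)nn3c(NC4CCCC4)cccc23)n1`: compound 2 gives 46000 nM
- compound 3 `Fc1ccc(-c2nn3c(NC4CCCC4)cccc3c2-c2cccnc2)cc1`: compound 3 gives > 40000 nM, which is a limit of the assay

Compound 3 stands at the upper limit of this assay; its value is a limit and not a number, and it is the single entry of the three that carries one (the limit of > 40000 nM in this assay, at which 1 of the 3 values shown sits). Compound 2 gives a number that sits near that same limit. Among the measured compounds shown here, the only measured step, a step that the limit leaves unreadable from compound 2 to compound 3, cannot be read in size, since the limit of compound 3 hides where it ends. Compound 1 adds no reading.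

The compound to be measured is compound 4 `Fc1ccc(-c2nn3c(NC4CCCC4)cccc3c2-c2cn[nH]c2)cc1`. It differs from compound 3 in one place: 1H-pyrazol-4-yl in place of pyridin-3-yl on an aromatic carbon. For the measured compounds named here, no measured step bears directly on this change; the step from compound 2 to compound 3 is the only one recorded and it is unreadable. What the two measured values show is that both compounds sit at or near the limit of this assay, so a step within the scatter is expected, and compound 4 is estimated at 45000 nM, with a range of 20000 nM to 100000 nM. The step that the limit leaves unreadable from compound 3 to compound 4 that this estimate means is expected to be too small to read, and it is likely that compound 4 again returns only a limit.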

Compound 4, half-maximal cytotoxic concentration: 10000 nM
For compound 4 the middle estimate is 4.5-fold (0.65 log units) above the measured one, and the stated range ends above it.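

At this place on the shared core, on the aromatic carbon next to the ring atom that bears a 4-fluorophenyl group, this assay now responds to the group carried: 1H-pyrazol-4-yl in place of pyridin-3-yl gives an at least 4.0-fold lower number from compound 3 to compound 4 (0.60 log units; beyond the scatter). Among the compounds shown here, the same group in place of 2-aminopyrimidin-4-yl gives a 4.6-fold lower number from compound 2 to compound 4 (0.66 log units; beyond the scatter), which is the first step with a readable size and shows that not every aromatic ring here stays near the top of the range, with the lower number standing for higher toxicity in this test. The step that ends at compound 4 and starts from compound 3 gives only a minimum size, and the step between compound 2 and compound 3 cannot be read, because compound 3 carries a limit and not a number: the limit of > 40000 nM in this assay, at which 1 of the 4 values shown sits.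

The change from pyridin-3-yl to 1H-pyrazol-4-yl alters ring size, hetero atoms and hydrogen-bond donors at once, so these compounds do not show which of them goes with the lower number. A 1-methyl-1H-pyrazol-4-yl group at this place, which would keep the five-membered ring and replace the ring hydrogen on nitrogen with a methyl group, remains an open case in this assay.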